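Swapping the Benzimidazole Substituent on a Trifluoromethyl Compound

The source may report more compounds than this note shows. Statements on the series, on what has been measured and on what is new or still open speak of the compounds shown alone.

Measured in a functional assay on A2780 cells (Homo sapiens) for inhibition, read by sulforhodamine B assay; on this read-out lower numbers stand for stronger inhibition of growth and higher numbers for weaker inhibition of growth:
- compound 1 `Cc1ccc2[nH]c(-c3ccc(-c4ccc(-c5ccc(N(C)C)cc5)cc4)cc3)nc2c1`: 2210 nM
- compound 2 `Oc1cccc2[nH]c(-c3ccc(-c4ccc(-c5ccccc5)cc4)cc3)nc12`: 41000 nM
- compound 3 `Oc1cccc2[nH]c(-c3ccc(-c4ccc(-c5ccc(C(F)(F)F)cc5)cc4)cc3)nc12`: 6100 nM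

Of these three, compound 3 holds the middle place, with compound 1 lower and compound 2 higher. Compound 4 `Cc1ccc2[nH]c(-c3ccc(-c4ccc(-c5ccc(C(F)(F)F)cc5)cc4)cc3)nc2c1` keeps the trifluoromethyl group, but 5-methyl-1H-benzimidazol-2-yl replaces 4-hydroxy-1H-benzimidazol-2-yl: 5-methyl-1H-benzimidazol-2-yl in place of 4-hydroxy-1H-benzimidazol-2-yl on an aromatic carbon.

Among the measured compounds shown here, no measured step covers this swap. The only one, a 6.7-fold lower number from compound 2 to compound 3 (0.83 log units; beyond the scatter), concerns trifluoromethyl in place of hydrogen, so it offers no direct guide. Compound 1 carries the entering group and gives 2210 nM, but it also differs from compound 4 in another group, so this is weak evidence. A small move to a lower number is therefore expected in this assay, a 2.2-fold lower number from compound 3 to compound 4 (0.34 log units; beyond the scatter). For compound 4 the estimated value is 2800 nM, within an expected range of 800 nM to 9000 nM.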

Compound 4, concentration for 50% growth inhibition: 12300 nM
Compound 4: the middle estimate sits 4.4-fold (0.64 log units) below what was measured, outside the stated range (above it).
By their numbers in this assay, from the lowest: compound 1; then compounds 3 and 4 (each within the scatter of the next); then compound 2.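

In this assay, the swap to 5-methyl-1H-benzimidazol-2-yl brings a 2.0-fold higher number from compound 3 to compound 4 (0.30 log units; within the scatter) so with trifluoromethyl in place, the two benzimidazole groups cannot be told apart. A change elsewhere does register: with 5-methyl-1H-benzimidazol-2-yl held fixed, trifluoromethyl in place of dimethylamino brings a 5.6-fold higher number from compound 1 to compound 4 (0.75 log units; beyond the scatter) as a clear step. Nothing measured here explains either result.

From the compounds shown here alone, whether the benzimidazole swap stays this small alongside hydrogen or dimethylamino remains open. So does how an amine or a carboxylic acid would read in place of trifluoromethyl.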